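A few compounds are considered here, and "the series" means these few. Any claim that something is new, unique, unknown or untested is made for them only; others in the source may bear on it.

In a functional assay on the whole organism with Rattus norvegicus as the target (on this read-out higher numbers stand for an effect only at larger amounts of compound and lower numbers for an effect already at smaller amounts), two compounds sharing one core have been measured so far. Compound 1 `Nc1nc2ccc(I)cc2s1` is reported only as a limit, > 10 mg/kg. For the measured compounds named here, compound 2 `CCCCCCc1ccc2nc(N)sc2c1` gives 7 mg/kg, the only actual number available, so its standing rests on no second numerical value. Compound 3 `Nc1nc2ccc(CC(F)(F)F)cc2s1` keeps the shared core and differs from compound 2 at one place trifluoromethyl in place of pentyl on a saturated chain carbon bound to an aromatic carbon. Going by the values given here, no measured pair shows a change of this kind, so the expectation is tentative. In this assay, no step beyond the usual scatter is expected, with only a slight lean towards a smaller dose. The expected step of a 1.4-fold lower number from compound 2 to compound 3 (0.15 log units; within the scatter) is therefore small. Compound 3 is estimated at 5 mg/kg, with an expected range of 2 mg/kg to 12 mg/kg.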

Compound 3, dose for half-maximal effect: 8 mg/kg
Compound 3: the middle estimate sits 1.6-fold (0.20 log units) below what was measured; the measured number falls inside the stated range.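

In this assay, a saturated chain carbon bound to an aromatic carbon now has a second measured substituent, and replacing pentyl with trifluoromethyl there gives a 1.1-fold higher number from compound 2 to compound 3 (0.06 log units; within the scatter), so this change leaves the dose within the usual scatter. Placing 2,2,2-trifluoroethyl in place of iodo on an aromatic carbon gives an at least 1.2-fold lower number from compound 1 to compound 3 (0.09 log units; that floor lies within the scatter). That step is only a floor, because compound 1 is known only as a limit: the limit of > 10 mg/kg in this assay, at which 1 of the 3 values shown sits.

The compounds shown leave open whether an amine, a carboxylic acid or a longer chain at this saturated chain carbon would also stay within the scatter of compound 2 in this assay. From the compounds shown here alone, how large the step from iodo to 2,2,2-trifluoroethyl really is also stays open, since only its floor is available.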